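A few compounds are considered here, and "the series" means these few. Any claim that something is new, unique, unknown or untested is made for them only; others in the source may bear on it.

Values so far in a functional assay on HepG2 cells (Homo sapiens) for inhibition, read by scintillation counting, with a stated time of 2 h; a higher number here means a weaker inhibitor, a lower number a stronger inhibitor
- compound 1 `CCNC(=O)Nc1sc2ccccc2c1C(=O)N1CCN(C2CCN(C(=O)OC(C)C)CC2)CC1` gives 208 nM
- compound 2 `CCNC(=O)Nc1sc2ccccc2c1C(=O)N1CCN(C2CCN(C(=O)OC3CCCC3)CC2)CC1` gives 512 nM

Compound 2, at 512 nM in this assay, holds the higher of these two numbers, which makes it the weaker inhibitor of the pair.

Compound 3 `CCNC(=O)Nc1sc2ccccc2c1C(=O)N1CCN(C2CCN(C(=O)OC(C)(C)C)CC2)CC1` has not yet been measured. It carries tert-butyl in place of cyclopentyl on an oxygen next to a carbonyl group.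

Among the measured compounds shown here, only one measured step bears on this change. Putting cyclopentyl in place of isopropyl at the same place gave a 2.5-fold higher number from compound 1 to compound 2 (0.39 log units; beyond the scatter), a modest step. Tert-butyl has no ring, and neither has the isopropyl of compound 1, which gives 208 nM in this assay. For the measured compounds named here, a modest step back towards a lower number therefore seems likely, although a single step is thin evidence and no measured compound yet carries tert-butyl.

The expected change is a 1.9-fold lower number from compound 2 to compound 3 (0.28 log units; within the scatter) in this assay, and this is only an estimate. For compound 3 the estimated value is 270 nM, with an expected range of 110 nM to 650 nM.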

Compound 3, half-maximal inhibitory concentration: 79 nM
For compound 3 the middle estimate is 3.4-fold (0.53 log units) above the measured one; the measured number lies below the stated range.
By their numbers in this assay, from the lowest: compound 3; then compound 1; then compound 2.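

In this assay tert-butyl on an oxygen next to a carbonyl group gives the strongest inhibitor of the three, with a 6.5-fold lower number from compound 2 to compound 3 (0.81 log units; beyond the scatter) and with a 2.6-fold lower number from compound 1 to compound 3 (0.42 log units; beyond the scatter) as the two steps that set it apart. The second of these steps shows that dropping the ring of cyclopentyl is not the whole story, since isopropyl and tert-butyl both have no ring and still differ by more than the scatter. At this place, then, a methyl in place of hydrogen on the carbon bound to the oxygen lowers the number, whereas cyclopentyl in place of isopropyl raises it, so small changes in the carbon group can move the number either way, and nothing available here accounts for this order.

The compounds shown leave open how other groups at this place would rank, such as cyclopropyl, benzyl or a longer chain like n-butyl. They also leave open whether the oxygen itself matters, which a plain amide carrying tert-butyl on the carbonyl carbon would help to test.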